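Swapping an Acid Chain for an Aromatic Ring

The compounds below may be only part of what the source reports. "The series", "measured", "known", "first", "only" and "open" are said of these compounds alone.

Three compounds built on one shared core were tested in a functional assay on MCF7 cells (Homo sapiens) for antiproliferative activity, read by MTT assay, with a stated time of 72 h; a higher number here means a weaker inhibitor, a lower number a stronger inhibitor. Compound 1 `CC1=CC[C@H]2[C@H](CC[C@]2(C)O)C(C)(C)[C@@H]1CC[C@H]1[C@]2(C)CC[C@H](OC(=O)CCC(=O)O)C(C)(C)O[C@H]2CC[C@@]1(C)O` carries a 2-carboxyethyl group on a carbonyl carbon whose other neighbour is an oxygen next to a carbonyl group. In this assay compound 1 gives > 50000 nM, which is a limit of the assay rather than a measured number. Compound 2 `CC1=CC[C@H]2[C@@H]1CC=C(C)[C@@H](CC[C@H]1[C@]3(C)CC[C@H](OCc4ccccc4)C(C)(C)O[C@H]3CC[C@@]1(C)O)C2(C)C` also reaches only a limit in this assay, > 50000 nM. For the measured compounds named here, compound 3 `CC1=CC[C@H]2[C@H](CC[C@]2(C)O)C(C)(C)[C@@H]1CC[C@H]1[C@]2(C)CC/C(=N/OC(=O)c3ccccc3)C(C)(C)O[C@H]2CC[C@@]1(C)O` is the one compound with a number, giving 25600 nM in this assay. Going by the values given here, compound 1 thus stands at the limit of > 50000 nM in this assay, at which 2 of the 3 values shown sit, and no two of the three compounds differ in just one place, so no measured step is available to guide the next change.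

Compound 4 `CC1=CC[C@H]2[C@H](CC[C@]2(C)O)C(C)(C)[C@@H]1CC[C@H]1[C@]2(C)CC[C@H](OC(=O)c3ccccc3C(F)(F)F)C(C)(C)O[C@H]2CC[C@@]1(C)O` differs from compound 1 in one spot: 2-(trifluoromethyl)phenyl in place of 2-carboxyethyl on a carbonyl carbon. Since compound 1 is only a limit, the step from compound 1 to compound 4 is expected to be small or to move toward stronger inhibition, as an at least 1.6-fold lower number from compound 1 to compound 4 (0.22 log units; that floor lies within the scatter) expresses. Compound 4 is estimated at 30000 nM, with a likely range from 8000 nM to 60000 nM.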

Compound 4, half-maximal inhibitory concentration: 19200 nM
Estimate against measurement, compound 4: 1.6-fold (0.19 log units) above; low and high end bracket the measured number.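

For the compounds shown here, this is the first readable step, and it shows that the carbonyl carbon whose other neighbour is oxygen next to a carbonyl group responds to what it carries. In this assay, placing 2-(trifluoromethyl)phenyl there in place of 2-carboxyethyl gives an at least 2.6-fold lower number from compound 1 to compound 4 (0.41 log units; beyond the scatter). Compound 1 is only a limit, so this step has a floor but no known full size: the limit of > 50000 nM in this assay, at which 2 of the 4 values shown sit.

The swap removes the 2-carboxyethyl group and brings in the aromatic ring and the trifluoromethyl group all at once, and the compounds shown do not separate these parts. Going by these compounds, it remains open whether an unsubstituted phenyl ring or a chain ending in an amine on this carbonyl carbon would give a similar number.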